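A tert-Butyl Replaces Methoxy in an Unresponsive Series

A few compounds are considered here, and "the series" means these few. Any claim that something is new, unique, unknown or untested is made for them only; others in the source may bear on it.

Compound 1 `COc1ccc(NC(=O)Nc2cc(C)nc3ccccc23)cc1` is the reference point. In an ADME assay on BJ cells (Homo sapiens) for cytotoxicity, with a stated time of 72 h (a lower number here means that less compound is needed, a higher number that more compound is needed for the effect), compound 1 reaches only a limit of the assay, giving > 25000 nM. Two close relatives have been measured alongside it. Compound 2 `COc1ccc(NC(=O)Nc2cc(C)nc3ccccc23)cc1F` carries fluoro in place of hydrogen on an aromatic carbon, and in this assay compound 2 gives 26000 nM. Compound 3 `COc1ccc(NC(=O)Nc2cc(C)nc3ccccc23)cc1OC` carries methoxy in place of hydrogen on an aromatic carbon, and in this assay compound 3 likewise gives only a limit, > 25000 nM. On these data alone, none of the three steps among them can be sized: a step that the limit leaves unreadable from compound 1 to compound 2, a step that the two limits leave unreadable from compound 1 to compound 3 and a step that the limit leaves unreadable from compound 2 to compound 3 all remain open because of the limit of > 25000 nM in this assay, at which 2 of the 3 values shown sit.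

Compound 4 `Cc1cc(NC(=O)Nc2ccc(C(C)(C)C)cc2)c2ccccc2n1` differs from compound 1 by tert-butyl in place of methoxy on an aromatic carbon. The measured steps bear on it only in one way: each change made so far left the read-out in this assay at or near the assay limit, so no step beyond the scatter is expected in either direction. Compound 4 is therefore expected to give about 30000 nM, somewhere between 15000 nM and 60000 nM, and most probably to be reported as a limit once more. The step this estimate implies, a step that the limit leaves unreadable from compound 1 to compound 4, is expected to stay within the scatter.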

Compound 4, half-maximal effective concentration: 20000 nM
The estimate for compound 4 lay 1.5-fold (0.18 log units) above the measured number; low and high end bracket the measured number.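

Among the compounds shown here, compound 4 is the only compound here in which the methoxy itself is exchanged, since compound 2 and compound 3 both keep it, so it gives the first view of what happens when the group on this aromatic carbon, para to a large group, is replaced. In this assay, tert-butyl in place of methoxy gives an at least 1.2-fold lower number from compound 1 to compound 4 (0.09 log units; that floor lies within the scatter). For the compounds shown here, that floor means the exchange of a methoxy carrying a hydrogen-bond acceptor for a tert-butyl carrying none may amount to no real change at all or to a larger one, and the data show only that the read-out for compound 4 is a number rather than a limit.

On these data alone, the true size of this step stays open because compound 1 is recorded only as a limit: the limit of > 25000 nM in this assay, at which 2 of the 4 values shown sit. Also open is whether an amine, a carboxylic acid or a longer chain on this same aromatic carbon would bring the number clearly beyond the scatter, and in which direction it would go.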